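The compounds below may be only part of what the source reports. "The series", "measured", "known", "first", "only" and "open" are said of these compounds alone.

Measured so far:

- Compound 1, `Cc1cc(NC(=O)Nc2ccc(N)cc2)c2ccccc2n1`. In an ADME assay on HEK293 cells (Homo sapiens) for cytotoxicity, with a stated time of 72 h (a higher number here means that more compound is needed for the effect, a lower number that less compound is needed), compound 1 gives > 25000 nM, which is a limit of the assay rather than a number.
- Compound 2, `Cc1cc(NC(=O)Nc2cccc(Cl)c2)c2ccccc2n1`. In this assay compound 2 gives 21000 nM.
- Compound 3, `Cc1cc(NC(=O)Nc2ccc(O)cc2)c2ccccc2n1`. In this assay compound 3 gives > 25000 nM, again only a limit.

Compound 3 thus stands at the ceiling of what this assay reports, and the limit of > 25000 nM in this assay, at which 2 of the 3 values shown sit, is shared with compound 1, so the two cannot be set apart. Against compound 2 the step is an at least 1.1-fold higher number from compound 2 to compound 3 (0.07 log units; that floor lies within the scatter), a floor that stays within the scatter.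

Compound 4, `Cc1cc(NC(=O)Nc2ccc(N(C)C)cc2)c2ccccc2n1`, differs from compound 3 by dimethylamino in place of hydroxy on an aromatic carbon. The measured step at this same position is a step that the two limits leave unreadable from compound 1 to compound 3, which two limits leave unreadable. The other two steps, an at least 1.1-fold lower number from compound 1 to compound 2 (0.07 log units; that floor lies within the scatter) and an at least 1.1-fold higher number from compound 2 to compound 3 (0.07 log units; that floor lies within the scatter), swap the whole aryl group and are both only floors within the scatter. Every measured compound therefore sits near or at the ceiling, and nothing points to a move beyond the scatter.

Compound 4 is expected to give about 25000 nM in this assay, within 12000 nM to 50000 nM. The step this estimate means, a number no higher from compound 3 to compound 4 (the limit leaves the size open), is expected to stay within the scatter, most likely as another limit.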

Compound 4, half-maximal effective concentration: > 25000 nM
Compound 4: a limit, no number; the forecaster's own chance of this, stated with the estimate: 60%; the middle value sits exactly at the limit.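

In this assay compound 4 gives > 25000 nM, again a limit of the assay and not a number. Its steps from compound 1 and compound 3 therefore cannot be read: the limit of > 25000 nM in this assay, at which 3 of the 4 values shown sit. The compounds shown leave open the actual numbers for compound 1, compound 3 and compound 4, and so whether amino, hydroxy and dimethylamino differ at all here.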